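Compound 2 to compound 4: iodo in place of nitro

The source may hold more compounds than are shown below. What is called first, only, known or untested is meant among the compounds shown, and "the series" means these compounds.

Going by the values given here, in a functional assay on K562 cells (Homo sapiens) for cytotoxicity, read by MTT assay, with a stated time of 72 h (a lower number here means a stronger inhibitor, a higher number a weaker inhibitor), compound 2 `CC(CC[C@H]1/C(=C/c2ccc([N+](=O)[O-])cc2)CC[C@H]2C(C)(C)CCC[C@]12C)CC(=O)O` gives 169000 nM, the only actual number in this small set. Compound 1 `C=C1CC[C@H]2C(C)(C)CCC[C@]2(C)[C@H]1CCC(C)CC(=O)O` gives > 200000 nM, which is a limit. Compound 3 `COc1ccc(/C=C2\CC[C@H]3C(C)(C)CCC[C@]3(C)[C@H]2CCC(C)CC(=O)O)cc1OC` gives > 200000 nM, which is also a limit. Little room for an upward move from compound 2 remains because of the limit of > 200000 nM in this assay, at which 2 of the 3 values shown sit.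

Compound 4 `CC(CC[C@H]1/C(=C/c2ccc(I)cc2)CC[C@H]2C(C)(C)CCC[C@]12C)CC(=O)O` differs from compound 2 by iodo in place of nitro on an aromatic carbon, so 4-nitrophenyl becomes 4-iodophenyl.

Among the compounds with values here, the one measured step at this aryl group is an at least 1.1-fold higher number from compound 2 to compound 3 (0.07 log units; that floor lies within the scatter), where 3,4-dimethoxyphenyl replaces 4-nitrophenyl. That step gives only a floor, and the floor lies within the scatter. No shift beyond the scatter is therefore expected in this assay, in either direction, and the assay may report only a limit. The expected change is a 1.1-fold lower number from compound 2 to compound 4 (0.02 log units; within the scatter), which stays within the scatter. For compound 4 the estimate is 160000 nM, with an expected range of 70000 nM to 280000 nM.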

Compound 4, half-maximal inhibitory concentration: 55000 nM
Compound 4: the middle estimate sits 2.9-fold (0.46 log units) above what was measured; measured number outside the range, below it.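

In this assay, going by these compounds alone, this aromatic position can move the number beyond the scatter, which the earlier compounds could not show: the change of nitro to iodo gives a 3.1-fold lower number from compound 2 to compound 4 (0.49 log units; beyond the scatter). Replacing the 3,4-dimethoxyphenyl group with the 4-iodophenyl group gives an at least 3.6-fold lower number from compound 3 to compound 4 (0.56 log units; beyond the scatter), so both comparisons point the same way for the iodo compound. The second step is only a floor, and its full size cannot be read: the limit of > 200000 nM in this assay, at which 2 of the 4 values shown sit.

From the compounds shown here alone, it remains open whether bromo, chloro or an amine at this place on the aromatic ring would follow iodo or stay with nitro. Going by these compounds, it is also open whether the shift seen for compound 4 would hold with a methyl ester in place of the carboxylic acid at the end of the chain.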